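This account rests on a few compounds, and the source may have more. Where it says the series, first, only, none or still open, it means among the compounds named here.

Measured so far:
compound 1, `Nc1ccccc1NC(=O)c1ccc(CSC(=S)N2CCc3ccc([N+](=O)[O-])cc32)cc1`: 42%
compound 2, `CC1CCN(C(=S)SCc2ccc(C(=O)Nc3ccccc3N)cc2)CC1`: 87.4%
compound 3, `COc1ccc(N2CCN(C(=S)SCc3ccc(C(=O)Nc4ccccc4N)cc3)CC2)cc1`: 35.9%

All three share a core, and they part only in the group attached to the thiocarbonyl carbon. In a functional assay on A-375 cells (Homo sapiens) for antiproliferative activity, read by CCK-8 assay, with a stated time of 72 h, tested at 8 uM (a higher number here means a stronger effect of the compound at the concentration tested, a lower number a weaker effect), compound 2 gives 87.4%, the highest of the three numbers. Compound 1 comes nearest, and its value of 42% lies beyond the scatter below compound 2. Compound 3 stands furthest, its value of 35.9% also beyond the scatter below compound 2. Compound 2 thus stands alone at the top of this small set.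

Compound 4, `CN(Cc1ccncc1)C(=S)SCc1ccc(C(=O)Nc2ccccc2N)cc1`, has not yet been measured in this assay. It differs from compound 2 in one place: methyl((pyridin-4-yl)methyl)amino in place of 4-methylpiperidin-1-yl on a thiocarbonyl carbon. Within the data shown here, since no two measured compounds differ in a single place, no measured step shows what such a swap does; the only guide is that the two compounds bearing an aromatic ring near the thiocarbonyl carbon, compound 1 and compound 3, sit well below compound 2. On that basis a downward step a number 32.4 percentage points lower from compound 2 to compound 4 (beyond the scatter) is expected for compound 4, larger than the scatter. Compound 4 is estimated to give 55% in this assay, within a range from 30% to 80%.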

Compound 4, a percentage reported as inhibition, at one concentration (the size of the read-out at that concentration, not a potency): 86.1%
For compound 4 the middle estimate is 31.1 percentage points below the measured one, outside the stated range (above it).
By their numbers in this assay, from the lowest: compounds 3 and 1 (each within the scatter of the next); then compounds 4 and 2 (each within the scatter of the next).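

In this assay, putting methyl((pyridin-4-yl)methyl)amino in place of 4-methylpiperidin-1-yl on a thiocarbonyl carbon gives a number 1.3 percentage points lower from compound 2 to compound 4 (within the scatter) and so leaves the read-out effectively unchanged. This is the first pair in the set that is linked by a single listed change, and it shows that this position can take a quite different group without a shift beyond the scatter: a six-membered non-aromatic ring leaves, while a six-membered aromatic ring with 1 hetero atom and a hydrogen-bond acceptor enters. Nothing shown here accounts for why the read-out holds across this change.

The read-out comes from one concentration, so it gives the size of the effect at that concentration and cannot show whether compound 2 and compound 4 also match in potency. From the compounds shown here alone, it also remains open how this position would respond to a group carrying a primary amine or a carboxylic acid, or to a longer chain such as butyl in place of the methyl on the nitrogen of compound 4.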